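The source may hold more compounds than are shown below. What is called first, only, known or untested is meant among the compounds shown, and "the series" means these compounds.

Of the compounds shown here, three sharing one core have been measured in a functional assay on M21 cells (Homo sapiens) for antiproliferative activity, read by sulforhodamine B assay, with a stated time of 48 h; on this read-out higher numbers stand for weaker inhibition of growth and lower numbers for stronger inhibition of growth. Compound 1 `COc1ccc(-c2cc(N3CCC(CCNS(N)(=O)=O)CC3)ncn2)cc1` gives 69800 nM. Compound 2 `NS(=O)(=O)NCCC1CCN(c2cc(-c3ccc(C(F)(F)F)cc3)ncn2)CC1` gives 34800 nM. Compound 3 `COC(=O)c1ccc(-c2cc(N3CCC(CCNS(N)(=O)=O)CC3)ncn2)cc1` gives 19600 nM. Compound 3 holds the lowest of these three numbers: the step from compound 1 to compound 3 is a 3.6-fold lower number from compound 1 to compound 3 (0.55 log units; beyond the scatter), while the gap from compound 2 to compound 3 is a 1.8-fold lower number from compound 2 to compound 3 (0.25 log units; within the scatter), so compound 3 and compound 2 cannot be told apart on these measurements.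

Compound 4 `CCOC(=O)c1ccc(-c2cc(N3CCC(CCNS(N)(=O)=O)CC3)ncn2)cc1` is the next compound. Its difference from compound 3 is methyl in place of hydrogen on a saturated chain carbon bound to an oxygen next to a carbonyl group. Among the compounds with values here, none of the measured steps touches this spot: the three measured steps, a 2.0-fold lower number from compound 1 to compound 2 (0.30 log units; within the scatter) among them, all swap one whole group for another on an aromatic carbon, whereas this change turns the methoxycarbonyl group into an ethoxycarbonyl group and leaves everything else untouched. With nothing measured to guide it, such a change is expected to give a step within the scatter, a 1.2-fold lower number from compound 3 to compound 4 (0.09 log units; within the scatter), and it could fall on either side of compound 3. Compound 4 is therefore estimated at 16000 nM in this assay, with a range from 6000 nM to 45000 nM.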

Compound 4, concentration for 50% growth inhibition: 9000 nM
Estimate against measurement, compound 4: 1.8-fold (0.25 log units) above, within the range that was stated.
By their numbers in this assay, from the lowest: compound 4; then compounds 3, 2 and 1 (each within the scatter of the next, the first and the last beyond it).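

Going from methoxycarbonyl to ethoxycarbonyl adds a single carbon, yet in this assay it gives a 2.2-fold lower number from compound 3 to compound 4 (0.34 log units; beyond the scatter), so this saturated chain carbon bound to an oxygen next to a carbonyl group is a place where even a small addition registers, something the earlier swaps of whole groups on the aromatic carbon could not show. Against trifluoromethyl and methoxy on that aromatic carbon, ethoxycarbonyl shows a 3.9-fold lower number from compound 2 to compound 4 (0.59 log units; beyond the scatter) and a 7.8-fold lower number from compound 1 to compound 4 (0.89 log units; beyond the scatter), which makes the ethoxycarbonyl compound the strongest inhibitor of growth of the four, a clear separation that methoxycarbonyl did not reach against trifluoromethyl. Nothing available here says what lies behind the gain from the added methyl.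

As far as these compounds go, what stays open is whether a longer chain on the same oxygen, such as propyl or butyl, or a branched isopropyl group, would lower the number further or lose the gain. From the compounds shown here alone, it is equally open whether a carboxylic acid or a primary amide in place of the ester would hold this level of growth inhibition.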